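Diacetylated sulfonamides and a shorter fluorinated side chain

A few compounds are considered here, and "the series" means these few. Any claim that something is new, unique, unknown or untested is made for them only; others in the source may bear on it.

Compound 1 `O=S(=O)(/C=C/c1ccc(O)c(O)c1)NCCCc1ccccc1` gives 17500 nM in a functional assay on BV-2 cells (Mus musculus) for inhibition, read by Griess assay, with stated times of 3 h and 24 h; on this read-out higher numbers stand for weaker inhibition and lower numbers for stronger inhibition. Compound 2 `CC(=O)Oc1ccc(/C=C/S(=O)(=O)NCCCc2ccccc2)cc1OC(C)=O` gives 15600 nM in this assay, the lower of the two numbers, though compound 1 sits only within the scatter of it. Compound 3 `CC(=O)Oc1ccc(/C=C/S(=O)(=O)NCc2ccc(F)cc2)cc1OC(C)=O` differs from compound 2 by 4-fluorophenyl in place of phenethyl on a saturated chain carbon bound to a sulfonamide nitrogen. Within the data shown here, no measured pair shows this change, so the step from compound 2 is expected to stay within the scatter, with no clear direction. Compound 3 is therefore estimated at 15000 nM, between 6000 nM and 40000 nM, a step of a 1.0-fold lower number from compound 2 to compound 3 (0.02 log units; within the scatter).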

Compound 3, half-maximal inhibitory concentration: 15500 nM
The estimate for compound 3 lay 1.0-fold (0.01 log units) below the measured number; the range from low to high includes it.
By their numbers in this assay, from the lowest: compounds 3, 2 and 1 (each within the scatter of the next).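

In this assay, among these compounds, 4-fluorophenyl in place of phenethyl gives a 1.0-fold lower number from compound 2 to compound 3 (0.00 log units; within the scatter), the first reading at this position on a saturated chain carbon bound to a sulfonamide nitrogen. The change from 3-phenylpropyl to 4-fluorobenzyl thus leaves the number within the scatter. No measurement shown bears on this result. Going by these compounds, the fluorine and the chain length change together here, and their separate contributions remain open. Also open, on these data alone, is whether an amine or a carboxylic acid at this position would move the number beyond the scatter.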